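Fluoro for Methoxy on the Aryl Ether of Compound 2

The source may report more compounds than this note shows. Statements on the series, on what has been measured and on what is new or still open speak of the compounds shown alone.

The two compounds measured here share a core that carries a thiourea-linked pyridyl group on a piperidine and a diaryl ether. Compound 1 `FC(F)(F)Oc1ccc(Oc2ccnc(N3CCC(NC(=S)Nc4cccnc4)CC3)c2Cl)c(Cl)c1` in an assay on membranes from brain for binding affinity to Lysophosphatidylserine lipase ABHD12 (Mus musculus), read by fluorescence, with a stated time of 20 min (a higher number here means a weaker inhibitor, a lower number a stronger inhibitor), gives 11 nM. Compound 2 `COc1ccc(Oc2ccnc(N3CCC(NC(=S)Nc4cccnc4)CC3)c2)cc1` in this assay gives 2900 nM, the highest of the two numbers shown, and its gap to compound 1 is well beyond the scatter. Within the data shown here, the two differ in several places at once, so their values say only that compound 1 is the stronger inhibitor of the pair.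

Compound 3 `Fc1ccc(Oc2ccnc(N3CCC(NC(=S)Nc4cccnc4)CC3)c2)cc1` differs from compound 2 in one place: fluoro in place of methoxy on an aromatic carbon, para to a large group. Among the measured compounds shown here, no measured step of this kind stands among the known compounds, so the size of the change is open. Compound 3 is estimated at 1500 nM, within 400 nM to 6000 nM, which means an expected step from compound 2 to compound 3 of a 1.9-fold lower number from compound 2 to compound 3 (0.29 log units; within the scatter), a modest move toward a stronger inhibitor, possibly not beyond the scatter.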

Compound 3, half-maximal inhibitory concentration: 1400 nM
Compound 3: the middle estimate sits 1.1-fold (0.03 log units) above what was measured, and the stated range covers the measured number.
By their numbers in this assay, from the lowest: compound 1; then compound 3; then compound 2.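

The step at this place on the aryl ether gives a 2.1-fold lower number from compound 2 to compound 3 (0.32 log units; beyond the scatter) in this assay, a modest move toward a stronger inhibitor. It shows that this position, para to a large group, accepts the exchange of methoxy, with its two heavy atoms and one hydrogen-bond acceptor, for fluoro, with one heavy atom and none, and that inhibition improves slightly rather than being lost. No measurement at hand accounts for the direction or the size of this step.

This is a single exchange on a single pair, so it cannot show whether the same step would hold on the core of compound 1, and the several differences that set compound 1 apart from compound 2 remain unseparated. Going by these compounds, how an amine, a nitrile, a carboxylic acid or a longer chain such as ethoxy would fare at this same aromatic carbon also remains open, as does whether the ordering of methoxy and fluoro is part of any wider trend at this position.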